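Piperazinyl for piperidinyl on the ethyl chain of compound 1

This account rests on a few compounds, and the source may have more. Where it says the series, first, only, none or still open, it means among the compounds named here.

Compound 1 `c1ccc2c(c1)CN[C@@H](CN(CC[C@@H]1CCCNC1)[C@H]1CCCc3cccnc31)C2` gives 161 nM in a functional assay on CCRF-CEM cells for antagonist activity at C-X-C chemokine receptor type 4 (Homo sapiens), read by calcium flux, with stated times of 25 min and 90 s (on this read-out lower numbers stand for stronger inhibition and higher numbers for weaker inhibition), the second highest of the three numbers measured. Compound 2 `c1cnc2c(c1)CCC[C@@H]2N(CCCN1CCNCC1)Cc1cc2ccccc2cn1` gives 17 nM in this assay, and compound 3 `c1cnc2c(c1)CN[C@H](CN(CCCN1CCNCC1)[C@H]1CCCc3cccnc31)C2` gives 2640 nM. Among the compounds with values here, the one single-point step among them, a 160-fold higher number from compound 2 to compound 3 (2.19 log units; beyond the scatter), concerns the group on a saturated chain carbon bound to an amine nitrogen, not the side chain. Compound 4 `c1ccc2c(c1)CN[C@@H](CN(CCN1CCNCC1)[C@H]1CCCc3cccnc31)C2` differs from compound 1 by piperazin-1-yl in place of piperidin-3-yl on a saturated chain carbon, two bonds along the chain from an amine nitrogen. Within the data shown here, no measured step bears directly on this change; compound 3 carries a piperazine but differs from compound 1 in two places, so it gives no clean guide. A step of small size, a 1.6-fold higher number from compound 1 to compound 4 (0.19 log units; within the scatter), is therefore expected. Compound 4 is estimated at 250 nM, within a range from 60 nM to 1000 nM.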

Compound 4, half-maximal inhibitory concentration: 553 nM
Estimate against measurement, compound 4: 2.2-fold (0.34 log units) below, within the range that was stated.
By their numbers in this assay, from the lowest: compound 2; then compound 1; then compound 4; then compound 3.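

In this assay, within the data shown here, piperazin-1-yl in place of piperidin-3-yl on the saturated chain carbon gives a 3.4-fold higher number from compound 1 to compound 4 (0.54 log units; beyond the scatter) and so shows that the side chain responds to the ring it carries, which the one earlier step, made in another group, could not show. The change also removes the defined stereocentre of piperidin-3-yl, and this single step cannot separate that loss from the change of ring. Nothing given here accounts for the step. From the compounds shown here alone, it remains open how morpholin-4-yl or piperidin-4-yl would compare on this chain. Also open, going by these compounds, is whether the opposite stereoisomer of piperidin-3-yl would match compound 1.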